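The source may hold more compounds than are shown below. What is called first, only, known or untested is meant among the compounds shown, and "the series" means these compounds.

Series notes. The shared core is that of compound 1 `O=C1N/C(=N/c2csc(-c3ccc(Cl)cc3)c2)S/C1=C\c1ccccc1`; compound 2 `COc1ccc(/C=C2\S/C(=N\c3csc(-c4ccc(Cl)cc4)c3)NC2=O)cc1` carries a methoxy where compound 1 carries hydrogen, and compound 3 `Cc1ccc(/C=C2\S/C(=N\c3csc(-c4ccc(Cl)cc4)c3)NC2=O)cc1` is the next member to be run. Within the data shown here, in a functional assay on MCF7 cells (Homo sapiens) for cytotoxicity, read by MTT assay, with a stated time of 72 h (a lower number here means a stronger inhibitor, a higher number a weaker inhibitor), compound 2 gives 1000 nM, the only plain number so far. For compound 1 the result is a limit of the assay, > 50000 nM. The evidence bearing on the measured step is the limit of > 50000 nM in this assay, at which 1 of the 2 values shown sits. Among the measured compounds shown here, the single measured step, an at least 50-fold lower number from compound 1 to compound 2 (1.69 log units; beyond the scatter), is thus large but read against a limit, so its true size is open. The change now at hand is methyl in place of methoxy on an aromatic carbon. As counted, the methyl keeps a group at the same place as in compound 2 but brings no acceptor and one heavy atom fewer; the step from compound 1 to compound 2 shows that removing the whole group costs a great deal, so a partial loss of what the methoxy contributes is expected here. Compound 3 is expected to be weaker than compound 2 in this assay, with an expected step of a 5.0-fold higher number from compound 2 to compound 3 (0.70 log units; beyond the scatter). Compound 3 is estimated at 5000 nM, in the range 1500 nM to 30000 nM.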

Compound 3, half-maximal inhibitory concentration: 900 nM
The estimate for compound 3 lay 5.6-fold (0.74 log units) above the measured number; measured number outside the range, below it.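

In this assay the change from 4-methoxyphenyl to 4-methylphenyl gives a 1.1-fold lower number from compound 2 to compound 3 (0.05 log units; within the scatter), so at this place, para to a large group, the oxygen and the acceptor that leave with the methoxy make no visible difference to the read-out. Methyl in place of hydrogen gives an at least 55-fold lower number from compound 1 to compound 3 (1.74 log units; beyond the scatter), which shows that the large gain first seen with methoxy is also reached with methyl and does not depend on an acceptor at this place. As far as these compounds go, the true size of that gain stays open, because compound 1 is a limit of the assay: the limit of > 50000 nM in this assay, at which 1 of the 3 values shown sits.

Methyl and methoxy alone cannot show whether any group at this place suffices or only some do, and a chlorine, a hydroxyl, an amine, a carboxylic acid or a longer chain such as ethyl would each test this differently. Also open, from the compounds shown here alone, is whether the level shared by compound 2 and compound 3 can be passed at this place, or whether further gains would have to come from elsewhere on the shared core.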